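The source may hold more compounds than are shown below. What is called first, only, known or untested is meant among the compounds shown, and "the series" means these compounds.

In a functional assay on KB cells (Homo sapiens) for antiproliferative activity, read by MTT assay, with a stated time of 72 h (on this read-out lower numbers stand for stronger inhibition and higher numbers for weaker inhibition), compound 1 (`CCOC(=O)c1cc(-c2cc(OC)c(OC)c(OC)c2)c(-c2cccc(Br)c2)s1`) gives > 100000 nM, which is a limit of the assay and not a number. Compound 3 (`CCOC(=O)c1cc(-c2cc(OC)c(OC)c(OC)c2)c(-c2ccc3ccccc3c2)s1`) has naphthalen-2-yl in place of 3-bromophenyl on an aromatic carbon. Compound 2 (`CCOC(=O)c1cc(-c2cc(OC)c(OC)c(OC)c2)c(-c2ccc(OC)c([N+](=O)[O-])c2)s1`) gives 15800 nM with a different group at that carbon. This single measured step bears on the change: an at least 6.3-fold lower number from compound 1 to compound 2 (0.80 log units; beyond the scatter). It involves another group, so only a modest move towards a lower number is expected, an estimated at least 3.3-fold lower number from compound 1 to compound 3 (0.52 log units; beyond the scatter). For compound 3 the expected value is 30000 nM, with an estimated range of 6000 nM to 100000 nM.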

Compound 3, half-maximal inhibitory concentration: 5890 nM
Estimate against measurement, compound 3: 5.1-fold (0.71 log units) above; the whole stated range lies above it.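

At this carbon next to the ring sulfur in this assay, a purely carbon two-ring group goes further than either substituted phenyl: an at least 16-fold lower number from compound 1 to compound 3 (1.22 log units; beyond the scatter) and a 2.7-fold lower number from compound 2 to compound 3 (0.43 log units; beyond the scatter). A lower number here therefore needs neither the methoxy nor the nitro group of compound 2. The first step has no upper end, because compound 1 gives only a limit and not a number: the limit of > 100000 nM in this assay, at which 1 of the 3 values shown sits.

From the compounds shown here alone, it remains open whether naphthalen-1-yl would match naphthalen-2-yl at this carbon. Going by these compounds, it is also open how an amine or a hydroxyl group on the naphthalene rings would shift the number.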